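This account rests on a few compounds, and the source may have more. Where it says the series, first, only, none or still open, it means among the compounds named here.

Three compounds have been measured in an ADME assay on A549 cells (Homo sapiens) for cytotoxicity, read by resazurin assay, with a stated time of 48 h; a higher number here means that more compound is tolerated, a lower number that less compound is tolerated:

compound 1 `CCCCCCCCC(C)Nc1ccc(NC(=O)c2cc(Cl)ccc2O)c(Cl)c1` gives 21900 nM
compound 2 `O=C(Nc1ccc(NCc2ccc(C(F)(F)F)cc2)cc1Cl)c1cc(Cl)ccc1O` gives 62700 nM
compound 3 `CC(C)(CCO)Nc1ccc(NC(=O)c2cc(Cl)ccc2O)c(Cl)c1` gives 170000 nM

Compound 2 stands second highest of the three numbers in this assay. Compound 3 gives the highest number and compound 1 the lowest, and compound 2 sits between them, with both of its gaps going beyond the usual scatter, so the three compounds span a real spread of tolerated concentrations around a shared core.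

The next compound to be measured is compound 4 `CC(C)(C)OC(=O)NCCNc1ccc(NC(=O)c2cc(Cl)ccc2O)c(Cl)c1`. It differs from compound 2 in one place: ((tert-butoxycarbonyl)amino)methyl in place of 4-(trifluoromethyl)phenyl on a saturated chain carbon bound to a nitrogen on an aromatic ring. Among the measured compounds shown here, no measured pair with this same change exists, so the size of the step has to be judged from the spread already seen. Compound 1 and compound 3 show that the group on the nitrogen on the aromatic ring shifts the tolerated concentration across a range beyond the scatter, and compound 3 shows that a chain without a ring sits at the high end of that range. On this basis compound 4 is expected to give a somewhat higher number than compound 2, an upward step that may reach beyond the scatter but is not expected to be large.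

The estimate for compound 4 in this assay is 100000 nM, with a range from 45000 nM to 220000 nM. This estimate means an expected step of a 1.6-fold higher number from compound 2 to compound 4 (0.20 log units; within the scatter).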

Compound 4, half-maximal cytotoxic concentration: 25000 nM
Compound 4: the middle estimate sits 4.0-fold (0.60 log units) above what was measured; measured number outside the range, below it.
By their numbers in this assay, from the lowest: compounds 1 and 4 (each within the scatter of the next); then compound 2; then compound 3.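

Putting ((tert-butoxycarbonyl)amino)methyl in place of 4-(trifluoromethyl)phenyl on a saturated chain carbon bound to a nitrogen on an aromatic ring gives, in this assay, a 2.5-fold lower number from compound 2 to compound 4 (0.40 log units; beyond the scatter), the first step read at this place. It shows that removing the aromatic ring from this group does not in itself bring a higher number: compound 4 gives 25000 nM, while compound 3, whose group also has no ring, gives 170000 nM, so groups without a ring occupy both ends of the values seen here. Nothing at hand explains why this exchange lowers the tolerated concentration.

The compounds shown leave open which part of the entering group carries the step, and whether a free amine in place of the tert-butoxycarbonyl-protected nitrogen would give a number nearer to that of compound 2 or compound 4. They also leave open how a plain phenyl, or a phenyl bearing a carboxylic acid, would behave at this place, which would separate the part played by the ring from that of the trifluoromethyl.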